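Ring in place of carbamoylmethyl on the chain

The source may report more compounds than this note shows. Statements on the series, on what has been measured and on what is new or still open speak of the compounds shown alone.

Measured in an ADME assay on microsomes from liver (Homo sapiens) for metabolic stability (on this read-out higher numbers stand for a longer-lived compound and lower numbers for a shorter-lived compound), all values being limits:
Compound 1 `CC(C)C(Cc1nnn[nH]1)c1ccc(-c2ccc3cccc(F)c3c2)[nH]c1=O`: > 3 h
Compound 2 `CC(C)C(c1noc(=O)[nH]1)c1ccc(-c2ccc3cccc(F)c3c2)[nH]c1=O`: > 3 h
Compound 3 `CC(C)C(CC(N)=O)c1ccc(-c2ccc3cccc(F)c3c2)[nH]c1=O`: < 0.0667 h

Compound 3 stands at the limit of < 0.0667 h in this assay, at which 1 of the 3 values shown sits. Compounds 1 and 2 stand at the limit of > 3 h in this assay, at which 2 of the 3 values shown sit.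

Compound 4 `CC(C)C(/C=C1\CCNC1=O)c1ccc(-c2ccc3cccc(F)c3c2)[nH]c1=O` differs from compound 3 as follows: a group of 7 heavy atoms (5 carbon, 1 nitrogen, 1 oxygen; one five-membered non-aromatic ring with 1 hetero atom) in place of a group of 4 heavy atoms (2 carbon, 1 nitrogen, 1 oxygen; no ring), on a saturated chain carbon bound to an aromatic carbon and a saturated chain carbon.

Two large measured steps bear on this change: an at least 44-fold lower number from compound 1 to compound 3 (1.65 log units; beyond the scatter) and an at least 44-fold lower number from compound 2 to compound 3 (1.65 log units; beyond the scatter). Both start from a five-membered aromatic ring, whereas the entering group has a five-membered non-aromatic ring, a type absent from the measured compounds. Those steps therefore give only weak guidance, and a small rise in this assay is expected, not a return to the upper limit. The expected change is an at least 1.7-fold higher number from compound 3 to compound 4 (0.25 log units; that floor lies within the scatter). Compound 4 is estimated at 0.12 h, with a range of 0.04 h to 0.6 h.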

Compound 4, half-life: 0.713 h
Compound 4: the middle estimate sits 5.9-fold (0.77 log units) below what was measured; measured number above the stated range.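

In this assay, a ring without aromatic character can take the place of carbamoylmethyl on the saturated chain carbon and still lift the read-out, giving an at least 10-fold higher number from compound 3 to compound 4 (1.02 log units; beyond the scatter). That ring does not match the two aromatic rings, with an at least 4.2-fold lower number from compound 2 to compound 4 (0.62 log units; beyond the scatter) and an at least 4.2-fold lower number from compound 1 to compound 4 (0.62 log units; beyond the scatter). As far as these compounds go, all three steps rest on limits of the assay, so their true sizes remain unknown.

From the compounds shown here alone, whether the rise follows the ring or the double bond outside it remains open. A carboxylic acid or a simple amine on the same chain would give further comparisons at this position.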